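This account rests on a few compounds, and the source may have more. Where it says the series, first, only, none or still open, it means among the compounds named here.

Compound 2 `CC(=O)c1ccc(Nc2ccnc(SCC(=O)c3ccc(Cl)cc3)n2)cc1` has been measured in a functional assay on KM12 cells (Homo sapiens) for inhibition, read by sulforhodamine B assay, with a stated time of 48 h, tested at 10 uM (a lower number here means less inhibition of growth, a higher number more inhibition of growth at the concentration tested), where compound 2 gives 11%. Within the data shown here, that is the lower of the two numbers known here. Compound 1 `CCOC(=O)c1ccc(Nc2ccnc(SCC(=O)c3ccc(C#N)cc3)n2)cc1` differs from it in more than one place, and in this assay compound 1 gives 45%, a reading that lies beyond the usual scatter above compound 2. Compound 3 `CC(=O)c1ccc(Nc2ccnc(SCC(=O)c3ccc(-c4ccccc4)cc3)n2)cc1` is not yet measured. It arises from compound 2 by one change: phenyl in place of chloro on an aromatic carbon. Among the measured compounds shown here, no measured pair shows this change, so only a small step, a number 9 percentage points higher from compound 2 to compound 3 (within the scatter), is expected, likely within the usual scatter. Compound 3 is therefore estimated at 20%, with a range from 0% to 50%.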

Compound 3, percent growth inhibition at one concentration: 24%
Compound 3: middle estimate off by 4 percentage points, on the low side; the measured number falls inside the stated range.
By their numbers in this assay, from the lowest: compound 2; then compound 3; then compound 1.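

Putting phenyl in place of chloro on this aromatic carbon, para to a large group, raises the reading in this assay modestly (a number 13 percentage points higher from compound 2 to compound 3 (beyond the scatter)). This position therefore tolerates an added six-membered aromatic ring without any loss of growth inhibition, which compound 1 and compound 2 alone could not show. Nothing available explains this rise. From the compounds shown here alone, how an amine or a carboxylic acid would read at this position remains open. So does whether phenyl would have a similar effect on the rest of compound 1.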